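Benzyl extension on the amino nitrogen of compound 3

The source may hold more compounds than are shown below. What is called first, only, known or untested is meant among the compounds shown, and "the series" means these compounds.

Compound 3 `CNc1ncc(C(=O)O)c2nc(-c3ccco3)nn12` sits at a limit of the assay: in a functional assay on CHO cells for antagonist activity at adenosine receptor A2b (Homo sapiens) (a higher number here means a weaker inhibitor, a lower number a stronger inhibitor), compound 3 gives > 10000 nM, a limit and not a number. Compound 1 `CCOC(=O)c1cnc(NC2CCCC2)n2nc(-c3ccco3)nc12` gives 4620 nM. Compound 2 `CCOC(=O)c1cnc(NC2CCCCC2)n2nc(-c3ccco3)nc12` gives > 10000 nM, which is again a limit. Going by the values given here, the only measured step in the set, an at least 2.1-fold higher number from compound 1 to compound 2 (0.33 log units; beyond the scatter), concerns the group on the same nitrogen; the limit of > 10000 nM in this assay, at which 2 of the 3 values shown sit, marks where two of the three values stand. Compound 4 `COc1ccc(CNc2ncc(C(=O)O)c3nc(-c4ccco4)nn23)cc1` carries 4-methoxyphenyl in place of hydrogen on a saturated chain carbon bound to a nitrogen on an aromatic ring. Since enlargement of the nitrogen substituent gave an at least 2.1-fold higher number from compound 1 to compound 2 (0.33 log units; beyond the scatter), compound 4 is expected to shift no more than an at least 1.2-fold lower number from compound 3 to compound 4 (0.09 log units; that floor lies within the scatter), direction uncertain. Compound 4 is estimated at 8000 nM, within 2000 nM to 30000 nM, with a real chance of another limit.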

Compound 4, inhibition constant: > 30000 nM
Compound 4 ended at the assay's limit; the forecaster's own chance of this, stated with the estimate: 45%; at least 3.7-fold (0.57 log units) between middle value and limit.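

In this assay compound 3 gives > 10000 nM, a limit. Compound 4 gives > 30000 nM, also a limit, and no step can be read between compound 3 and compound 4. The compounds shown leave open whether methyl to 4-methoxybenzyl changes the inhibition in this assay at all.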